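The source may report more compounds than this note shows. Statements on the series, on what has been measured and on what is new or still open speak of the compounds shown alone.

Two members of the series have been examined in an ADME assay on HEK-293T cells (Homo sapiens) for cytotoxicity, read by MTT assay, with a stated time of 3 days; on this read-out higher numbers stand for lower toxicity in this test and lower numbers for higher toxicity in this test. Compound 1 `CC(C)(C)N(CCC(=O)c1ccccc1)C(=O)COC(=O)c1ccc([N+](=O)[O-])o1` is recorded in this assay as "not active" (no number reported), with no number behind it. Compound 2 `CC(C)(C)N(Cc1ccc([N+](=O)[O-])cc1)C(=O)COC(=O)c1ccc([N+](=O)[O-])o1` gives > 100000 nM in this assay, which is a limit of the assay and not a number. Among the measured compounds shown here, compound 2 thus stands at the limit of > 100000 nM in this assay, at which 1 of the 2 values shown sits, while the other entry carries no number at all, so no step between measured compounds can be drawn. The unmeasured compound 3 `CC(C)(C)N(Cc1ccc(OCc2ccccc2)cc1)C(=O)COC(=O)c1ccc([N+](=O)[O-])o1` differs from compound 2 by benzyloxy in place of nitro on an aromatic carbon. Nothing measured says what this change does to toxicity. For compound 3 the expectation in this assay is therefore no step beyond the usual scatter, expressed as a number no higher from compound 2 to compound 3 (the limit leaves the size open). The estimate for compound 3 is 100000 nM, within a range from 30000 nM to 300000 nM, and a further limit rather than a number is expected as the more likely report.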

Compound 3, half-maximal cytotoxic concentration: "not active" (no number reported)
Compound 3: no number reported; there is nothing to compare the estimate with.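

Among the compounds shown here, compound 3 is recorded without a number and compound 2 carries only a limit of the assay, so no step between them can be read in this assay. The compounds shown leave open what benzyloxy in place of nitro does to toxicity in this assay.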